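Swapping the pyridine attachment on a pyrazoline amide

The source may hold more compounds than are shown below. What is called first, only, known or untested is meant among the compounds shown, and "the series" means these compounds.

Compound 1 `Cn1cc(C2CC(c3ccccc3)=NN2C(=O)c2cccnc2)c2ccccc21`. In a functional assay on HeLa cells (Homo sapiens) for inhibition, read by MTT assay, with a stated time of 48 h (a higher number here means a weaker inhibitor of growth, a lower number a stronger inhibitor of growth), compound 1 gives only a limit, > 10000 nM.
Compound 2 `Cn1cc(C2CC(c3ccccc3)=NN2C(=O)c2ccncc2)c2ccccc21`. In this assay compound 2 gives 590 nM.
Compound 3 `COc1ccc(C2=NN(C(=O)c3cccnc3)C(c3cn(C)c4ccc(Br)cc34)C2)cc1OC`. In this assay compound 3 gives 2090 nM.

Compounds 1 and 2 share one core and differ in a single place: pyridin-4-yl in place of pyridin-3-yl on a carbonyl carbon. That change produced an at least 16-fold lower number from compound 1 to compound 2 (1.22 log units; beyond the scatter). The size of this step is bounded by the limit of > 10000 nM in this assay, at which 1 of the 3 values shown sits, so only its lower bound is known.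

Compound 3 carries a different core from compound 1; the difference between the two cores is not broken down here. Compound 4 `COc1ccc(C2=NN(C(=O)c3ccncc3)C(c3cn(C)c4ccc(Br)cc34)C2)cc1OC` has not yet been tested in this assay. It stands to compound 3 exactly as compound 2 stands to compound 1: pyridin-4-yl in place of pyridin-3-yl on a carbonyl carbon. The place of the change is the same in both pairs, so this is the same change, now made on the core of compound 3.

Among the compounds with values here, because an at least 16-fold lower number from compound 1 to compound 2 (1.22 log units; beyond the scatter) was large, a step in the same direction is expected for compound 4, though with only one earlier example, and that one a bound rather than a measured size, the expected step is kept more modest: a 7.0-fold lower number from compound 3 to compound 4 (0.84 log units; beyond the scatter). On that basis compound 4 is estimated to give 300 nM in this assay, with a plausible range from 70 nM to 1500 nM.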

Compound 4, concentration for 50% growth inhibition: > 10000 nM
Compound 4: only a limit was reported; the forecaster's own chance of this, stated with the estimate: 5%; middle value at least 33-fold (1.52 log units) away from the limit.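

On the core of compound 3, pyridin-4-yl in place of pyridin-3-yl on a carbonyl carbon gave an at least 4.7-fold higher number from compound 3 to compound 4 (0.67 log units; beyond the scatter), so a swap that lowered the number on the core of compound 1 raised it here. The same change therefore did not carry over from one core to the other in this assay, and the two steps run in opposite directions: the same change on two cores in this assay, an at least 16-fold lower number (1.22 log units; beyond the scatter) from compound 1 to compound 2 and an at least 4.7-fold higher number (0.67 log units; beyond the scatter) from compound 3 to compound 4, at least 81-fold (1.90 log units) apart, beyond the scatter of two such steps. This shows that the effect of the swap depends on the core in this small set, but it does not show how large either step really is, as compound 1 and compound 4 each give only a limit and not a true number: the limit of > 10000 nM in this assay, at which 2 of the 4 values shown sit.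

It remains open which part of the difference between the two cores decides the direction of the step, as no compound shown changes just one part of that difference. Also open, going by these compounds, is how a plain phenyl ring or a pyridin-2-yl group on the same carbonyl carbon would compare with the two pyridines on each core, which would show whether the reversal is special to this pair of groups.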